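A few compounds are considered here, and "the series" means these few. Any claim that something is new, unique, unknown or untested is made for them only; others in the source may bear on it.

Compound 2 `CCOC(=O)c1c(-c2cccc(O)c2)[nH]c2cc(OC)ccc2c1=O` and compound 1 `CCOC(=O)c1c(-c2cccc(Cl)c2)[nH]c2cc(OC)ccc2c1=O` share one core and differ by chloro in place of hydroxy on an aromatic carbon. In an ADME assay on HepG2 cells (Homo sapiens) for cytotoxicity, read by luminescence, with a stated time of 72 h (on this read-out higher numbers stand for an effect only at larger amounts of compound and lower numbers for an effect already at smaller amounts), compound 2 gives > 21500 nM, which is a limit of the assay rather than a number. In this assay compound 1 gives > 21500 nM, also a limit. The step that the two limits leave unreadable from compound 2 to compound 1 therefore cannot be sized. Compound 3 `CCOC(=O)c1c(-c2cccc(-c3ccccc3)c2)[nH]c2cc(O)ccc2c1=O` carries a different core; how it differs from compound 2 is not broken down here. In this assay compound 3 gives > 21500 nM, again a limit. Compound 4 `CCOC(=O)c1c(-c2cccc(-c3ccccc3)c2)[nH]c2cc(Cl)ccc2c1=O` is not yet measured and differs from compound 3 by chloro in place of hydroxy on an aromatic carbon, the same kind of change as before, though here the place is on a ring that is part of a fused or bridged system of two rings, meta to a fused ring and para to a fused ring, rather than meta to a large group. For compound 4 a step of a number no higher from compound 3 to compound 4 (the limit leaves the size open) is expected, resting on (the limit of > 21500 nM in this assay, at which 3 of the 3 values shown sit). Compound 4 is thus estimated at 21500 nM, between 9000 nM and 60000 nM.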

Compound 4, half-maximal effective concentration: > 21500 nM
Compound 4 ended at the assay's limit; the forecaster's own chance of this, stated with the estimate: 85%; the middle value lies on the limit itself.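

In this assay compound 3 and compound 4 both give only a limit, and the step between them cannot be read. The compounds shown leave open at what concentration, if any, each would become cytotoxic to these cells.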